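Replacing 3-methoxyphenyl with 4-fluorophenyl on an oxygen

A few compounds are considered here, and "the series" means these few. Any claim that something is new, unique, unknown or untested is made for them only; others in the source may bear on it.

In a functional assay on M21 cells (Homo sapiens) for antiproliferative activity, read by sulforhodamine B assay, with a stated time of 48 h (on this read-out higher numbers stand for weaker inhibition and lower numbers for stronger inhibition), three compounds sharing one core have been measured. Compound 1 `CCCN1CCN(c2ccc(S(=O)(=O)Oc3ccccc3C)cc2)C1=O` gives > 100000 nM, which is a limit of the assay and not a number. Compound 2 `CCCN1CCN(c2ccc(S(=O)(=O)Oc3ccc(C)cc3C)cc2)C1=O` gives 9700 nM. Compound 3 `CCCN1CCN(c2ccc(S(=O)(=O)Oc3cccc(OC)c3)cc2)C1=O` gives 10000 nM, and it stands level with the other measured number, the step being a 1.0-fold higher number from compound 2 to compound 3 (0.01 log units; within the scatter).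

Compound 4 `CCCN1CCN(c2ccc(S(=O)(=O)Oc3ccc(F)cc3)cc2)C1=O` now takes the comparison further, with 4-fluorophenyl in place of 3-methoxyphenyl on an oxygen. Going by the values given here, no measured compound carries fluorine, so only the steps that alter the group on this oxygen bear on the change. Two of them are wide, an at least 10-fold lower number from compound 1 to compound 2 (1.01 log units; beyond the scatter) and an at least 10-fold lower number from compound 1 to compound 3 (1.00 log units; beyond the scatter), and they show that this assay can respond strongly to this group. The step between compound 2 and compound 3 shows that quite different groups can also land together. Compound 1 is therefore the warning that a poor result remains possible, while the two measured numbers suggest the likelier level. The expected change is a 1.4-fold higher number from compound 3 to compound 4 (0.15 log units; within the scatter), which means no clear shift beyond the scatter, with a wider risk towards higher numbers. Compound 4 is estimated at 14000 nM, with an expected range from 4000 nM to 60000 nM.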

Compound 4, half-maximal inhibitory concentration: 14000 nM
Beside the measured number, compound 4's estimate shows no gap at the digits printed, within the range that was stated.
By their numbers in this assay, from the lowest: compounds 2, 3 and 4 (each within the scatter of the next). At a limit, above all of these: compound 1.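

In this assay, putting 4-fluorophenyl in place of 3-methoxyphenyl on the oxygen bound to the sulfonyl sulfur gives a 1.4-fold higher number from compound 3 to compound 4 (0.15 log units; within the scatter), and putting it in place of 2,4-dimethylphenyl gives a 1.4-fold higher number from compound 2 to compound 4 (0.16 log units; within the scatter), so a third differently substituted phenyl group joins the same level. Going by these compounds alone, that level now holds with fluorine, which no earlier compound carried, and without the hydrogen-bond acceptor counted for 3-methoxyphenyl, so among compound 2, compound 3 and compound 4 this acceptor is not required. Compound 1, with its 2-methylphenyl group, still stands apart, an at least 7.1-fold lower number from compound 1 to compound 4 (0.85 log units; beyond the scatter), and its value is a limit of the assay and not a number: the limit of > 100000 nM in this assay, at which 1 of the 4 values shown sits.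

The compounds shown leave open whether a phenyl group carrying an amine or a carboxylic acid on this oxygen would stay at this level or move away from it. They also leave open what a longer chain in place of the propyl group on the shared core would do, as all four compounds keep that propyl group unchanged.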